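Ring-amine series: benzyl in place of carboxythiophenylmethyl

A few compounds are considered here, and "the series" means these few. Any claim that something is new, unique, unknown or untested is made for them only; others in the source may bear on it.

Measured so far:
compound 1, `OC[C@@H](O[C@H]1CCCN(Cc2ccccc2Cc2nnco2)[C@H]1c1ccccc1)c1cc(Cl)cc(Cl)c1`, 3700 nM
compound 2, `O=C(O)c1ccc(CN2CCC[C@H](OCc3cc(Cl)cc(Cl)c3)[C@@H]2c2ccccc2)s1`, 76000 nM

Working notes. In an assay on isolated protein for activation of cGMP-dependent protein kinase 1 (Homo sapiens), read by ADP-Glo, with stated times of 120 min and 40 min (a lower number here means that less compound is needed, a higher number that more compound is needed for the effect), compound 1 gives 3700 nM, and in this assay compound 2 gives 76000 nM. Of the two numbers, compound 2 stands highest; the gap to compound 1 lies beyond the scatter. For the measured compounds named here, compound 1 and compound 2 differ in more than one place, so no single step is drawn between them; their values show only that the shared core tolerates a wide spread.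

Compound 3, `Clc1cc(Cl)cc(CO[C@H]2CCCN(Cc3ccccc3)[C@H]2c2ccccc2)c1`, is not yet measured. It is reached from compound 2 by one change: phenyl in place of 5-carboxythiophen-2-yl on a saturated chain carbon bound to an amine nitrogen in a ring. The group that leaves carries the only hydrogen-bond donor and both acceptors counted at that place; what enters is a plain phenyl.

Going by the values given here, no measured step covers this change. Compound 3 is expected to move toward a lower number than compound 2, by a step of a 3.8-fold lower number from compound 2 to compound 3 (0.58 log units; beyond the scatter) estimated as moderate and beyond the scatter, with compound 1 marking how far down this core can reach. Compound 3 is expected at 20000 nM, within 5000 nM to 80000 nM.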

Compound 3, half-maximal effective concentration: > 200000 nM
Compound 3 gave a limit, no number; the forecaster's own chance of this, stated with the estimate: 10%; at least 10-fold (1.00 log units) between middle value and limit.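

In this assay compound 3 gives > 200000 nM, which is a limit of the assay and not a number. For the compounds shown here, replacing 5-carboxythiophen-2-yl with phenyl on a saturated chain carbon bound to an amine nitrogen in a ring gives an at least 2.6-fold higher number from compound 2 to compound 3 (0.42 log units; beyond the scatter), the first change in a single place, and it shows that the group carried at this place affects the read-out, with the phenyl version requiring more compound. The size of this step is only a lower bound, and its true extent stays unknown, as it rests on a limit: the limit of > 200000 nM in this assay, at which 1 of the 3 values shown sits.

The change removes the carboxylic acid and replaces the thiophene ring with a benzene ring in one move, so the compounds shown do not separate the contribution of the acid from that of the ring; an unsubstituted thiophen-2-yl or a carboxyphenyl group would divide the step into these two parts. They also leave open whether a primary amide or an amine at this place would follow the carboxylic acid or the plain phenyl.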